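Indole dihydropyran series: 4-methylphenyl variant of compound 3

The source may hold more compounds than are shown below. What is called first, only, known or untested is meant among the compounds shown, and "the series" means these compounds.

Compound 3 `COc1ccc(C2C(C#N)=C(N)OC(c3c[nH]c4ccccc34)=C2C#N)cc1OC` gives 28.1% in a functional assay, tested at 400 ug/mL; a lower number here means a weaker effect, a higher number a stronger effect of the compound at the concentration tested. It is the largest of the three numbers, yet compound 1 `COc1cc(Br)c(C2C(C#N)=C(N)OC(c3c[nH]c4ccccc34)=C2C#N)cc1OC` gives 26.7% and compound 2 `N#CC1=C(N)OC(c2c[nH]c3ccccc23)=C(C#N)C1c1ccc(Br)cc1` gives 22.7%, and both gaps to compound 3 are within the scatter, so this assay does not separate the three compounds.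

Compound 4 `Cc1ccc(C2C(C#N)=C(N)OC(c3c[nH]c4ccccc34)=C2C#N)cc1` differs from compound 3 in one place: 4-methylphenyl in place of 3,4-dimethoxyphenyl on a saturated ring carbon.

For the measured compounds named here, two measured steps bear on this change. Hydrogen in place of bromo on an aromatic carbon gave a number 1.4 percentage points higher from compound 1 to compound 3 (within the scatter). 3,4-Dimethoxyphenyl in place of 4-bromophenyl on the saturated ring carbon gave a number 5.4 percentage points higher from compound 2 to compound 3 (within the scatter). Both lie within the scatter; so far the group on the saturated ring carbon has not moved the read-out beyond it. Compound 4 carries, like compound 2, a group with no hydrogen-bond acceptors on that carbon, and compound 2 gives 22.7%, which is the closest guide.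

The step from compound 3 to compound 4 is therefore expected to be a number 3.1 percentage points lower from compound 3 to compound 4 (within the scatter), nothing beyond the scatter. Compound 4 is estimated at 25%, with a range from 15% to 35%.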

Compound 4, a percentage reported as activity, at one concentration (the size of the read-out at that concentration, not a potency): 8.5%
Compound 4: middle estimate off by 16.5 percentage points, on the high side, outside the stated range (below it).
By their numbers in this assay, from the lowest: compound 4; then compounds 2, 1 and 3 (each within the scatter of the next).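

Unlike the earlier steps, which all stayed within the scatter, 4-methylphenyl in place of 3,4-dimethoxyphenyl on the saturated ring carbon gives a number 19.6 percentage points lower from compound 3 to compound 4 (beyond the scatter) in this assay and shows that this carbon's substituent can change the read-out. Methyl in place of bromo on the same aryl group gives a number 14.2 percentage points lower from compound 2 to compound 4 (beyond the scatter) as well, so a single substituent on that ring is enough to separate two compounds. The lack of hydrogen-bond acceptors cannot account for the low number on its own, as compound 2, whose 4-bromophenyl also has none, stays within the scatter of compound 3. Nothing available explains why the methyl compound falls away from the other three.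

On these data alone, it remains open whether the low number is specific to methyl or extends to other alkyl groups, which 4-ethylphenyl or 4-isopropylphenyl on the same carbon would test. Unsubstituted phenyl and 4-aminophenyl would show whether the methyl lowers the read-out or the bromo and the two methoxy groups each hold it up, and a single-concentration read-out gives no potency for any of these compounds.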